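Aryl swap on the anilino nitrogen: compound 3 to compound 4

This account rests on a few compounds, and the source may have more. Where it says the series, first, only, none or still open, it means among the compounds named here.

Measured so far:
Compound 1, `O=C(CSc1nc(Nc2ccccc2)c2ccccc2n1)Nc1ccccc1Br`: in a functional assay on NCI-H1975 cells (Homo sapiens) for inhibition, read by MTT assay, with a stated time of 72 h (on this read-out higher numbers stand for weaker inhibition and lower numbers for stronger inhibition), compound 1 gives 10300 nM.
Compound 2, `O=C(CSc1nc(Nc2ccccc2)c2ccccc2n1)Nc1ccc([N+](=O)[O-])cc1`: in this assay compound 2 gives 13000 nM.
Compound 3, `C=CC(=O)Nc1cccc(NC(=O)CSc2nc(Nc3ccccc3Br)c3ccccc3n2)c1`: in this assay compound 3 gives 19300 nM.

All three values sit within the scatter of one another; compound 3 is not separable from compound 1 or compound 2 on these numbers. Within the data shown here, the only single-point step available is a 1.3-fold higher number from compound 1 to compound 2 (0.10 log units; within the scatter), and it concerns the aryl on the amide-type nitrogen, not the nitrogen on the aromatic ring where the present change sits, so it bears only indirectly.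

Compound 4, `C=CC(=O)Nc1cccc(NC(=O)CSc2nc(Nc3cccc(C)c3)c3ccccc3n2)c1`, differs from compound 3 by 3-methylphenyl in place of 2-bromophenyl on a nitrogen on an aromatic ring. Among the measured compounds shown here, no measured pair probes an aryl exchange at this nitrogen. For the measured compounds named here, with the one comparable aryl exchange elsewhere falling within the scatter, a shift in this assay no larger than the scatter is expected, in no fixed direction. For compound 4 the estimate is 18000 nM, with a range of 8000 nM to 40000 nM, corresponding to an expected step of a 1.1-fold lower number from compound 3 to compound 4 (0.03 log units; within the scatter).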

Compound 4, half-maximal inhibitory concentration: 12100 nM
Compound 4: middle estimate off by 1.5-fold (0.17 log units), on the high side, within the range that was stated.
By their numbers in this assay, from the lowest: compounds 1, 4, 2 and 3 (each within the scatter of the next).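

Among these compounds, this is the first measured aryl exchange on the nitrogen on an aromatic ring: in this assay, 3-methylphenyl in place of 2-bromophenyl gives a 1.6-fold lower number from compound 3 to compound 4 (0.20 log units; within the scatter), a step within the scatter. At this position, then, the exchange of these two aryl groups, each with the same heavy-atom count and neither with hydrogen-bond donors or acceptors, does not separate the two compounds on this read-out. No measurement shown here offers an explanation for this result.

This single exchange alters both the substituent and the name's ring number, so the two contributions cannot be told apart. From the compounds shown here alone, whether an aryl group carrying an amine or a carboxylic acid on this nitrogen would give a step beyond the scatter remains open.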